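Azetidin-1-yl for pyrrolidin-1-yl: working notes on compound 3

The source may report more compounds than this note shows. Statements on the series, on what has been measured and on what is new or still open speak of the compounds shown alone.

In a functional assay on MCF7 cells (Homo sapiens) for antiproliferative activity, read by CCK-8 assay, with a stated time of 48 h (a higher number here means a weaker inhibitor, a lower number a stronger inhibitor), compound 1 `C/C=C/C(=O)N1CC(Oc2ccc(Oc3c(-c4ccc(F)cc4)sc4cc(O)ccc34)cc2)C1` gives 28000 nM and compound 2 `O=C(/C=C/CN1CC(Oc2ccc(Oc3c(-c4ccc(F)cc4)sc4cc(O)ccc34)cc2)C1)N1CCCC1` gives 8450 nM, the lower of the two numbers. Within the data shown here, the only measured step is a 3.3-fold lower number from compound 1 to compound 2 (0.52 log units; beyond the scatter), a modest move beyond the scatter, made by placing 3-((pyrrolidin-1-yl)carbonyl)prop-2-en-1-yl in place of (prop-1-en-1-yl)carbonyl on an amine nitrogen in a ring. Compound 3 `O=C(/C=C/CN1CC(Oc2ccc(Oc3c(-c4ccc(F)cc4)sc4cc(O)ccc34)cc2)C1)N1CCC1` differs from compound 2 in one place: azetidin-1-yl in place of pyrrolidin-1-yl on a carbonyl carbon, with azetidin-1-yl in place of pyrrolidin-1-yl on a carbonyl carbon. Among the measured compounds shown here, no measured step varies this group, so a 3.3-fold lower number from compound 1 to compound 2 (0.52 log units; beyond the scatter) offers only a rough scale. A smaller step is expected in this assay, probably none beyond the scatter, and its direction is uncertain. The expected change is a 1.1-fold higher number from compound 2 to compound 3 (0.05 log units; within the scatter). Compound 3 is estimated at 9500 nM, with an expected range of 4500 nM to 20000 nM.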

Compound 3, half-maximal inhibitory concentration: > 25000 nM
Compound 3: only a limit was reported; the forecaster's own chance of this, stated with the estimate: 5%; at least 2.6-fold (0.42 log units) between middle value and limit.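

Compound 3 is reported in this assay only as a limit, > 25000 nM, and not as a number: the limit of > 25000 nM in this assay, at which 1 of the 3 values shown sits.

Even so, the limit is enough to give a direction for this change: there is an at least 2.9-fold higher number from compound 2 to compound 3 (0.47 log units; beyond the scatter). The earlier compounds shown here did not vary the group on this carbonyl carbon, and here the exchange of pyrrolidin-1-yl for azetidin-1-yl, with the rest of the structure unchanged, is not neutral in this cell read-out; the step from compound 1 to compound 3 cannot be read.

As far as these compounds go, how far compound 3 lies past its limit remains open, as does its order against compound 1. Also open, from the compounds shown here alone, is how piperidin-1-yl, morpholin-4-yl or an open-chain dimethylamino group on the same carbonyl carbon would compare with pyrrolidin-1-yl.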